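Replacing a naphthalene on an unmeasured parent compound

The source may hold more compounds than are shown below. What is called first, only, known or untested is meant among the compounds shown, and "the series" means these compounds.

Compound 1 `CC1=C(CN2CC(C(=O)O)C2)CCc2cc(OCc3ccc4ccccc4c3)ccc21`: "not determined" (no result reported)
Compound 2 `COc1cc(COc2ccc3c(c2)CCC(CN2CC(C(=O)O)C2)=C3C)ccc1CC(C)C`: 0.034 mg/kg

The two compounds were examined in a functional assay on the whole organism (strain BALB/c) with Mus musculus as the target, with a stated time of 4 h (a lower number here means that less compound is needed, a higher number that more compound is needed for the effect), and only one of them gave a number. For compound 1 the entry reads "not determined" (no result reported) and so places it nowhere on the scale. Compound 2 gives 0.034 mg/kg as the sole measured reference point in this series.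

Compound 3 `COc1cc(C)ccc1COc1ccc2c(c1)CCC(CN1CC(C(=O)O)C1)=C2C` is the next to be tested. It keeps the core of compound 1 and changes one group, with 2-methoxy-4-methylphenyl in place of naphthalen-2-yl on a saturated chain carbon bound to an oxygen on an aromatic ring in the count of what leaves and enters.

With no number for compound 1, the size and direction of this step in this assay cannot be read from it. The expectation therefore leans on compound 2, which shares the core and also carries a methoxy group in that place, at 0.034 mg/kg in this read-out. A result of similar order or somewhat higher is expected. For compound 3 the estimated value is 0.1 mg/kg with an expected range from 0.03 mg/kg to 0.4 mg/kg in this assay.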

Compound 3, dose for half-maximal effect: > 0.1 mg/kg
Compound 3 was reported as a limit; the forecaster's own chance of this, stated with the estimate: 5%; the middle value lies on the limit itself.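

No new step can be read between compound 1 and compound 3, as compound 1 has no number to compare with. Compound 3 is reported only as a limit, not a number: the limit of > 0.1 mg/kg in this assay, at which 1 of the 3 values shown sits.

The compounds shown leave open how much the change from naphthalen-2-yl to 2-methoxy-4-methylphenyl alters the dose, and where compound 3 lies on the scale.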